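The compounds below may be only part of what the source reports. "The series", "measured", "known", "first", "only" and "open" are said of these compounds alone.

Measured so far:
Compound 1, `N#Cc1ccccc1-c1cccc(COc2ccc(S(=O)(=O)CC(=O)O)cc2)c1`: 457 nM
Compound 2, `O=C(O)CS(=O)(=O)c1cccc(OCc2ccc(-c3ccccc3)cc2)c1`: in the same test compound 2 reaches only a limit of the assay, > 1000 nM
Compound 3, `Cc1nc(-c2ccccc2F)sc1COc1ccc(S(=O)(=O)CC(=O)O)cc1`: 550 nM

All three compounds were tested in a functional assay on CHO cells for agonist activity at Free fatty acid receptor 1 (Homo sapiens), read by FLIPR and calcium flux; a lower number here means that less compound is needed, a higher number that more compound is needed for the effect. They share the same acid-bearing core, and differ in the aromatic group attached through the benzylic ether. Compound 3 has the higher of the two actual numbers, but the gap to compound 1 is small and lies within the usual scatter of repeated measurements, so the two cannot be told apart on this evidence. For compound 2 only a limit is known, which means that the measurement stopped before a number could be fixed.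

Compound 4, `Cc1cccc(-c2nc(C)c(COc3ccc(S(=O)(=O)CC(=O)O)cc3)s2)c1`, has not yet been measured. It differs from compound 3 in one place: 3-methylphenyl in place of 2-fluorophenyl on an aromatic carbon. For the measured compounds named here, no pair of measured compounds shows the effect of such a swap on this core, so there is no measured step to lean on. Without such a step the expectation is that this exchange moves the number little, in no definite direction, and not beyond the scatter. Compound 4 is therefore estimated at 500 nM, with a plausible range from 150 nM to 1600 nM, an expected step of a 1.1-fold lower number from compound 3 to compound 4 (0.04 log units; within the scatter).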

Compound 4, half-maximal effective concentration: 214 nM
Compound 4: the middle estimate sits 2.3-fold (0.37 log units) above what was measured; the measured number falls inside the stated range.
By their numbers in this assay, from the lowest: compound 4; then compounds 1 and 3 (each within the scatter of the next). At a limit, above all of these: compound 2.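

In this assay, for the compounds shown here, this is the first pair of compounds that differ in one place, and it shows that the aryl group on this aromatic carbon of the shared core is not a neutral spot: the change gives a 2.6-fold lower number from compound 3 to compound 4 (0.41 log units; beyond the scatter). The step is modest, yet it is a real one, even though 2-fluorophenyl and 3-methylphenyl have the same count of heavy atoms and neither has hydrogen-bond donors or acceptors. The swap alters both the group on the phenyl ring and where it sits on that ring, and nothing at hand explains the step or separates those two changes.

The compounds shown leave open which of the two changes matters, a question that 2-methylphenyl or 3-fluorophenyl on the same core could settle. They also leave open how far this position tolerates other groups on the phenyl ring, such as a methoxy group, an amine or a carboxylic acid, and whether the number would then keep falling or rise again.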